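A few compounds are considered here, and "the series" means these few. Any claim that something is new, unique, unknown or untested is made for them only; others in the source may bear on it.

Measured compounds:
compound 1 `CCCc1cc2ccccc2nc1-c1cn(-c2ccc(F)cc2)nn1`: > 100 ug/mL
compound 2 `CCCCc1cc2ccccc2nc1-c1cn(-c2ccc(F)cc2)nn1`: > 100 ug/mL
compound 3 `CCCc1cc2ccccc2nc1-c1cn(CCC(F)(F)C(F)(F)C(F)(F)C(F)(F)C(F)(F)C(F)(F)C(F)(F)C(F)(F)F)nn1`: > 100 ug/mL

In a functional assay on COLO 205 cells (Homo sapiens) for cytotoxicity, read by MTT assay, with a stated time of 24 h (on this read-out lower numbers stand for stronger inhibition and higher numbers for weaker inhibition), compound 1 gives > 100 ug/mL, which is a limit of the assay rather than a number. Compound 2 gives > 100 ug/mL, also a limit. The change between them, (methyl in place of hydrogen on a saturated chain carbon, three bonds along the chain from an aromatic carbon), therefore amounts to a step that the two limits leave unreadable from compound 1 to compound 2. Compound 3 gives > 100 ug/mL, again a limit. The difference between the cores of compound 1 and compound 3 is not broken down here. Compound 4 `CCCCc1cc2ccccc2nc1-c1cn(CCC(F)(F)C(F)(F)C(F)(F)C(F)(F)C(F)(F)C(F)(F)C(F)(F)C(F)(F)F)nn1` is not yet measured; it carries the same change, (methyl in place of hydrogen on a saturated chain carbon, three bonds along the chain from an aromatic carbon), at the same place. With every measured value sitting at the limit of > 100 ug/mL in this assay, at which 3 of the 3 values shown sit, the expected step is a step that the limit leaves unreadable from compound 3 to compound 4, and a number rather than a limit is unlikely. Compound 4 is expected to give about 150 ug/mL, most likely between 60 ug/mL and 500 ug/mL.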

Compound 4, half-maximal inhibitory concentration: > 100 ug/mL
Compound 4 gave a limit, no number; the forecaster's own chance of this, stated with the estimate: 85%; the middle value is on the limit's open side.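

Compound 4 gives > 100 ug/mL, which is a limit and not a number, so no step can be read between compound 3 and compound 4. The compounds shown leave open what number any of them would reach, and whether the chain change alters it: the limit of > 100 ug/mL in this assay, at which 4 of the 4 values shown sit.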